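Substituents on the aromatic nitrogen of the shared core

The compounds below may be only part of what the source reports. "The series", "measured", "known", "first", "only" and "open" are said of these compounds alone.

Measured so far:
- Compound 1 `O=C(Cn1nnc(-c2ccccc2)n1)NC1CC2CCC1C2`: in an assay on HEK293 cells for activation of Kir3.1/Kir3.2 (Homo sapiens), read by thallium flux (on this read-out higher numbers stand for an effect only at larger amounts of compound and lower numbers for an effect already at smaller amounts), compound 1 gives 1980 nM.
- Compound 2 `Cc1cc(NC(=O)Cn2nnc(-c3ccccc3)n2)n(C2CCC(C)(C)CC2)n1`: in this assay compound 2 gives > 221 nM, which is a limit of the assay and not a number.
- Compound 3 `CCC(C)n1nc(C)cc1NC(=O)Cn1nnc(-c2ccccc2)n1`: in this assay compound 3 gives > 5000 nM, again a limit of the assay.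

Among the compounds with values here, compound 2 therefore stands only at a limit; it is the one value sitting at the limit of > 221 nM in this assay, at which 1 of the 3 values shown sits, while compound 3 sits at the limit of > 5000 nM in this assay, at which 1 of the 3 values shown sits. Within the data shown here, the single step measured at the aromatic nitrogen, a step that the two limits leave unreadable from compound 2 to compound 3, runs between two limits and its size cannot be read. Among the measured compounds shown here, compound 1 gives the only numeric value in the set.

Compound 4 `Cc1cc(NC(=O)Cn2nnc(-c3ccccc3)n2)n(C2CCS(=O)(=O)C2)n1` differs from compound 2 by 1,1-dioxothiolan-3-yl in place of 4,4-dimethylcyclohexyl on an aromatic nitrogen. For the measured compounds named here, the only step that bears on this position is unreadable, so no direction or size can be derived from it, and the expectation rests on compound 2 being known solely as a limit. Compound 4 is expected to give about 3000 nM, within 500 nM to 20000 nM. The step that the limit leaves unreadable from compound 2 to compound 4 is thus an estimate, not a measured trend.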

Compound 4, half-maximal effective concentration: 1030 nM
Beside the measured number, compound 4's estimate is 2.9-fold (0.46 log units) above it; the range from low to high includes it.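

Within the data shown here, at the aromatic nitrogen of the shared core, compound 4 gives the first numeric value in this assay, 1030 nM. Placing 1,1-dioxothiolan-3-yl at this position in place of sec-butyl gives an at least 4.8-fold lower number from compound 3 to compound 4 (0.68 log units; beyond the scatter), so at this position, the change from an open chain to this ring bearing two oxygens goes with a lower number. Compound 2 stands only at a limit, so its steps to compound 3 and compound 4 cannot be read: the limit of > 221 nM in this assay, at which 1 of the 4 values shown sits.

The compounds shown leave open how 4,4-dimethylcyclohexyl and 1,1-dioxothiolan-3-yl rank against each other on this read-out, and whether the ring or its two oxygens carry the step from sec-butyl. Also open, from the compounds shown here alone, is how a plain thiolan-3-yl or a piperidin-4-yl amine at this nitrogen would read in this assay.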